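The compounds below may be only part of what the source reports. "The series", "measured", "known", "first", "only" and "open" are said of these compounds alone.

Going by the values given here, compound 2 `COc1cc(N)c(Cl)cc1C(=O)NC1CCN(CC2CCN(C(=O)C(C)N)CC2)CC1` is one of two compounds measured in an assay on striatum for inhibition of 5-hydroxytryptamine receptor 4 (Cavia porcellus), read by radioligand binding; a higher number here means a weaker inhibitor, a lower number a stronger inhibitor. There compound 2 gives 5.06 nM, and compound 1 `COc1cc(N)c(Cl)cc1C(=O)NC1CCN(CC2CCN(C(=O)CCCN)CC2)CC1` gives 3.99 nM, the two numbers lying within the scatter of each other. Among the compounds with values here, the only recorded step, a 1.3-fold higher number from compound 1 to compound 2 (0.10 log units; within the scatter), stays within the scatter. Compound 3 `COc1cc(N)c(Cl)cc1C(=O)NC1CCN(CC2CCN(C(=O)CN)CC2)CC1` differs from compound 2 by hydrogen in place of methyl on a saturated chain carbon bound to an amine nitrogen and a carbonyl carbon. Within the data shown here, that single step is the only one bearing on this change, and it moved nothing beyond the scatter, so the expected step is a 1.0-fold lower number from compound 2 to compound 3 (0.01 log units; within the scatter), with no shift beyond the scatter in this assay. Compound 3 is estimated to give 5 nM, with an expected range from 2 nM to 12.5 nM.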

Compound 3, half-maximal inhibitory concentration: 9.3 nM
Compound 3: the middle estimate sits 1.9-fold (0.27 log units) below what was measured; measured number inside the range.
By their numbers in this assay, from the lowest: compounds 1, 2 and 3 (each within the scatter of the next, the first and the last beyond it).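

In this assay, hydrogen in place of methyl on this saturated chain carbon stays within the scatter, with a 1.8-fold higher number from compound 2 to compound 3 (0.26 log units; within the scatter). Set against the 3-aminopropyl chain, however, the aminomethyl group gives the first step beyond the scatter in this series, a modest one, with a 2.3-fold higher number from compound 1 to compound 3 (0.37 log units; beyond the scatter). No measured evidence accounts for this difference. The compounds shown leave open how a dimethylamino group in place of the primary amine, or a longer chain such as 4-aminobutyl, would read in this assay.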